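The compounds below may be only part of what the source reports. "The series", "measured", "known", "first", "only" and "open" are said of these compounds alone.

Measured compounds and their values:

Compound 1, `Cn1c(=O)c2[nH]c(Cc3ccc(OCCCn4ccnc4)cc3)nc2n(C)c1=O`: > 30 nM

Compound 2, `Cn1c(=O)c2[nH]c(Cc3ccc(OCCCCl)cc3)nc2n(C)c1=O`: > 30 nM

In an assay on CHO cells for displacement of a labelled ligand from adenosine receptor A3 (Homo sapiens), read by scintillation counting, with a stated time of 3 h (a higher number here means a weaker inhibitor, a lower number a stronger inhibitor), compound 1 gives only a limit, > 30 nM. Compound 2 likewise gives only a limit, > 30 nM. Because both values sit at the limit of > 30 nM in this assay, at which 2 of the 2 values shown sit, the step that the two limits leave unreadable from compound 1 to compound 2 cannot be read, neither in size nor in direction. Compound 2 therefore stands at the limit of this assay, with no number of its own to place it against compound 1.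

Compound 3, `Cn1c(=O)c2[nH]c(Cc3ccc(OCCCN4CCC5(CC4)OCCO5)cc3)nc2n(C)c1=O`, differs from compound 2 in one place: a group of 10 heavy atoms (7 carbon, 1 nitrogen, 2 oxygen; one five-membered non-aromatic ring with 2 hetero atoms, one six-membered non-aromatic ring with 1 hetero atom) in place of one chlorine atom, on a saturated chain carbon, three bonds along the chain from an oxygen on an aromatic ring. For the measured compounds named here, no measured step bears on this change in a readable way, since the only step available, from compound 1 to compound 2, is hidden by two limits. With both known values at the limit, the expectation for this assay is that compound 3 may also reach only a limit, and any number it gives is expected to lie near or weaker than the limit rather than clearly stronger. The step that the limit leaves unreadable from compound 2 to compound 3 is thus an estimate with wide uncertainty. Compound 3 is estimated at 300 nM, between 30 nM and 5000 nM.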

Compound 3, inhibition constant: > 30 nM
Compound 3: no number, only a limit; the forecaster's own chance of this, stated with the estimate: 60%; the middle value lies beyond the limit too.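

In this assay compound 3 gives > 30 nM as its result, which is a limit and not a number. The steps linking compound 3 to compound 1 and compound 2 therefore cannot be read, in size or direction, because all three compounds sit at the same limit: the limit of > 30 nM in this assay, at which 3 of the 3 values shown sit.

The compounds shown leave open how strongly each one inhibits, and whether changing the group at the end of the chain alters that strength at all.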